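Replacing a trifluoromethyl group with chloro and fluoro

The source may report more compounds than this note shows. Statements on the series, on what has been measured and on what is new or still open speak of the compounds shown alone.

In an ADME assay on the whole organism (Rattus norvegicus, strain Sprague-Dawley) for pharmacokinetics, using cassette dosing, at a dose of 1 mg/kg by the oral route (a lower number here means that a smaller share of the oral dose reaches the circulation, a higher number that a larger share of the oral dose reaches the circulation), compound 3 (`O=C(Nc1ccc2[nH]c(=O)oc2c1)C(=O)N1CCN(c2ccc(C(F)(F)F)cc2)CC1`) gives 24.8% and so sits within the scatter of compound 1 (`O=C(c1cc(-c2ccc(=O)[nH]c2)on1)N1CCC(Cc2ccccc2)CC1`) at 18.4% but clearly under compound 2 (`O=C(Nc1ccc2[nH]c(=O)oc2c1)C(=O)N1CCN(c2ccc(F)cc2)CC1`) at 39.3% on this measure. Compound 4 (`O=C(Nc1ccc2[nH]c(=O)oc2c1)C(=O)N1CCN(c2ccc(F)c(Cl)c2)CC1`) brings one change: 3-chloro-4-fluorophenyl in place of 4-(trifluoromethyl)phenyl on an amine nitrogen in a ring. Going by the values given here, one measured step bears on it. With trifluoromethyl in place of fluoro, the result was a number 14.5 percentage points lower from compound 2 to compound 3 (beyond the scatter) and that step is modest though beyond the scatter. Among the compounds with values here, compound 4 gives up the trifluoromethyl and carries fluoro again, yet no measured compound here carries chloro. The expected change is a number 6.2 percentage points higher from compound 3 to compound 4 (within the scatter) and would stay within the scatter. Compound 4 is estimated at 31% with a likely range from 17% to 45% for now.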

Compound 4, oral bioavailability: 24.6%
The estimate for compound 4 lay 6.4 percentage points above the measured number, within the range that was stated.
By their numbers in this assay, from the lowest: compounds 1, 4 and 3 (each within the scatter of the next); then compound 2.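

In this assay, 3-chloro-4-fluorophenyl in place of 4-(trifluoromethyl)phenyl gives a number 0.2 percentage points lower from compound 3 to compound 4 (within the scatter), so on this ring nitrogen the two groups cannot be told apart by this measure. Adding chloro to the fluorophenyl ring gives a number 14.7 percentage points lower from compound 2 to compound 4 (beyond the scatter), so keeping fluoro does not by itself preserve the higher number of compound 2. The data offer no explanation for either step. Still open, as far as these compounds go, is whether a phenyl ring carrying methoxy or a nitrile, or chloro without fluoro, would come closer to compound 2 at 39.3% on this measure.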